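The source may hold more compounds than are shown below. What is called first, only, known or untested is meant among the compounds shown, and "the series" means these compounds.

Of the compounds shown here, three of the shared core have been measured so far. Compound 1 `CC(C)=CCC/C(C)=C/CC/C(C)=C/CC[C@@H]1[C@@]2(C)CC/C(=N\OCc3cn(-c4ccccc4)nn3)C(C)(C)[C@@H]2CC[C@@]1(C)O` gives 9520 nM in a functional assay on HepG2 cells (Homo sapiens) for cytotoxicity, read by MTT assay, with a stated time of 48 h; a higher number here means a weaker inhibitor, a lower number a stronger inhibitor; compound 2 `COc1cccc(-n2cc(CO/N=C3\CC[C@]4(C)[C@@H](CC/C=C(\C)CC/C=C(\C)CCC=C(C)C)[C@](C)(O)CC[C@H]4C3(C)C)nn2)c1` gives 51300 nM; compound 3 `CC(C)=CCC/C(C)=C/CC/C(C)=C/CC[C@@H]1[C@@]2(C)CC/C(=N\OCc3cn(-c4ccc(Cl)cc4)nn3)C(C)(C)[C@@H]2CC[C@@]1(C)O` gives 19900 nM. Compound 3 holds the second highest of the three numbers: a 2.1-fold higher number from compound 1 to compound 3 (0.32 log units; beyond the scatter), while a 2.6-fold lower number from compound 2 to compound 3 (0.41 log units; beyond the scatter). Compound 4 `CC(C)=CCC/C(C)=C/CC/C(C)=C/CC[C@@H]1[C@@]2(C)CC/C(=N\OCc3cn(-c4c(Cl)cc([N+](=O)[O-])cc4Cl)nn3)C(C)(C)[C@@H]2CC[C@@]1(C)O` differs from compound 3 in one place: 2,6-dichloro-4-nitrophenyl in place of 4-chlorophenyl on an aromatic nitrogen. Among the compounds with values here, the steps that bear on this are the two substitutions on the same aromatic ring, a 5.4-fold higher number from compound 1 to compound 2 (0.73 log units; beyond the scatter) and a 2.1-fold higher number from compound 1 to compound 3 (0.32 log units; beyond the scatter); each raised the number modestly, so a further modest rise beyond the scatter is expected for compound 4, though no measured step introduces a 2,6-dichloro-4-nitrophenyl. Compound 4 is therefore estimated at 35000 nM, range 12000 nM to 100000 nM. This estimate means a 1.8-fold higher number from compound 3 to compound 4 (0.25 log units; within the scatter) is expected.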

Compound 4, half-maximal inhibitory concentration: 34900 nM
Compound 4: the middle estimate sits 1.0-fold (0.00 log units) above what was measured, and the stated range covers the measured number.
By their numbers in this assay, from the lowest: compound 1; then compounds 3, 4 and 2 (each within the scatter of the next, the first and the last beyond it).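

In this assay, the 2,6-dichloro-4-nitrophenyl on the aromatic nitrogen cannot be told apart from either of the other two substituted phenyl groups: a 1.8-fold higher number from compound 3 to compound 4 (0.24 log units; within the scatter) and a 1.5-fold lower number from compound 2 to compound 4 (0.17 log units; within the scatter). Against the unsubstituted phenyl the change does register, with a 3.7-fold higher number from compound 1 to compound 4 (0.56 log units; beyond the scatter), so all three substituted rings shown give higher numbers than phenyl, and none goes against this. Nothing available gives a cause for these differences.

Which part of the new group carries that step stays open; a 4-nitrophenyl and a 2,6-dichlorophenyl would separate the parts. As far as these compounds go, whether an amine on this ring would give a lower number than phenyl also stays open.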